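Solubility of an alkyne-linked thiazole series: predicting compound 4

A few compounds are considered here, and "the series" means these few. Any claim that something is new, unique, unknown or untested is made for them only; others in the source may bear on it.

Measured compounds and their values in a physicochemical assay for solubility, read by spectrophotometry and turbidimetry, in phosphate buffer, with a stated time of 2 h; on this read-out lower numbers stand for lower solubility and higher numbers for higher solubility:
compound 1 `C/C(=N\NC(=N)N)c1sc(-c2ccc(C#Cc3ccccc3)cc2)nc1C` gives 2500 nM;
compound 2 `C/C(=N\NC(=N)N)c1sc(-c2ccc(C#Cc3cccc(O)c3)cc2)nc1C` gives 55000 nM;
compound 3 `C/C(=N\NC(=N)N)c1sc(-c2ccc(C#CC(C)(C)O)cc2)nc1C` gives 320000 nM.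

Compound 1 stands lowest of the three, with compound 2 nearest at a 22-fold higher number from compound 1 to compound 2 (1.34 log units; beyond the scatter) and compound 3 furthest at a 130-fold higher number from compound 1 to compound 3 (2.11 log units; beyond the scatter). Compound 4 `C/C(=N\NC(=N)N)c1sc(-c2ccc(C#Cc3ccc(C)s3)cc2)nc1C` differs from compound 1 by 5-methylthiophen-2-yl in place of phenyl on a triple-bonded carbon. Neither measured step bears directly on this change: both a 22-fold higher number from compound 1 to compound 2 (1.34 log units; beyond the scatter) and a 130-fold higher number from compound 1 to compound 3 (2.11 log units; beyond the scatter) came with a hydroxy group entering, whereas here no hydrogen-bond donor enters and the entering group is an aromatic ring of matching heavy-atom count. Compound 4 is therefore expected to stay near compound 1 in this assay, with a step of a 1.3-fold lower number from compound 1 to compound 4 (0.10 log units; within the scatter) not beyond the scatter. The estimate for compound 4 is 2000 nM, between 500 nM and 8000 nM.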

Compound 4, solubility: 12000 nM
Compound 4: middle estimate off by 6.0-fold (0.78 log units), on the low side; the measured number lies above the stated range.
By their numbers in this assay, from the lowest: compound 1; then compound 4; then compound 2; then compound 3.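

At this place, on a triple-bonded carbon, a change with no hydroxy group entering still gave a step beyond the scatter in this assay with a 4.8-fold higher number from compound 1 to compound 4 (0.68 log units; beyond the scatter) as the result. The hydroxy-bearing compounds nevertheless kept higher numbers, with a 4.6-fold lower number from compound 2 to compound 4 (0.66 log units; beyond the scatter) on one side and a 27-fold lower number from compound 3 to compound 4 (1.43 log units; beyond the scatter) on the other. Nothing available explains these steps.

The compounds shown leave open whether the methyl or the sulfur-containing five-membered ring carries the step. They also leave open where an amine or a carboxylic acid at this place would stand in this assay among these numbers.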